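A few compounds are considered here, and "the series" means these few. Any claim that something is new, unique, unknown or untested is made for them only; others in the source may bear on it.

Measured so far in a functional assay on HepG2 cells (Homo sapiens) for antiproliferative activity, read by MTT assay, with a stated time of 48 h; on this read-out higher numbers stand for weaker inhibition and lower numbers for stronger inhibition:
compound 1 `Fc1ccc(CNc2ccc3ncnc(Nc4cccc(Br)c4)c3c2)cc1` gives 1770 nM
compound 2 `Fc1ccc(CNc2ccc3ncnc(Nc4cccc(Cl)c4)c3c2)cc1` gives 2690 nM
compound 3 `Clc1ccc(CNc2ccc3ncnc(Nc4cccc(Cl)c4)c3c2)cc1` gives 1780 nM

All three values lie within the usual scatter of one another. The step of a 1.5-fold lower number from compound 2 to compound 1 (0.18 log units; within the scatter) goes with bromo in place of chloro on an aromatic carbon. The two cores differ by chloro in place of fluoro on an aromatic carbon, which gave the step of a 1.5-fold lower number from compound 2 to compound 3 (0.18 log units; within the scatter).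

Compound 4 `Clc1cccc(Nc2ncnc3ccc(NCc4ccc(Br)cc4)cc23)c1` is not yet measured. It differs from compound 3 by bromo in place of chloro on an aromatic carbon. This is the same kind of change as that from compound 2 to compound 1, not the same one: there the place is meta to a large group, here it is para to a large group.

The step of a 1.3-fold lower number from compound 3 to compound 4 (0.10 log units; within the scatter) is expected to stay within the scatter, resting on compound 2 and compound 1, where the same kind of change gave a 1.5-fold lower number from compound 2 to compound 1 (0.18 log units; within the scatter). Compound 4 is estimated at 1400 nM in this assay, expected between 700 nM and 2800 nM.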

Compound 4, half-maximal inhibitory concentration: 3810 nM
Beside the measured number, compound 4's estimate is 2.7-fold (0.43 log units) below it; measured number outside the range, above it.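

In this assay, bromo in place of chloro does not carry from one core to the other as a fixed step: the same change on two cores in this assay, a 1.5-fold lower number (0.18 log units; within the scatter) from compound 2 to compound 1 and a 2.1-fold higher number (0.33 log units; beyond the scatter) from compound 3 to compound 4, 3.3-fold (0.51 log units) apart, beyond the scatter of two such steps. Para to a large group, the change gives a 2.1-fold higher number from compound 3 to compound 4 (0.33 log units; beyond the scatter), whereas bromo in place of fluoro at that place gives a 1.4-fold higher number from compound 2 to compound 4 (0.15 log units; within the scatter). With one pair on each core, these results show that the two steps differ, but not why, nor whether the place of the change or the rest of the core accounts for the gap.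

The compounds shown carry only halogens at the two varied places. As far as these compounds go, a methoxy, nitrile or amine in place of the bromo of the 4-bromobenzyl group remains open, as does whether the higher number seen with bromo extends beyond compound 4.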